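Swapping Trifluoromethyl for Chloro on the Shared Core

The source may report more compounds than this note shows. Statements on the series, on what has been measured and on what is new or still open speak of the compounds shown alone.

Within the data shown here, compound 2 `O=C(O)c1cnc2c(C(F)(F)F)cccc2c1` is the one compound with an actual number in a functional assay on the whole organism (strain Sprague-Dawley) for inhibition, with Rattus norvegicus as the target (on this read-out lower numbers stand for an effect already at smaller amounts and higher numbers for an effect only at larger amounts of compound), where compound 2 gives 50 mg/kg. Compound 1 `FC(F)(F)c1cccc2cc(-c3nn[nH]n3)cnc12` gives only a limit of this assay, < 25 mg/kg. Among the measured compounds shown here, the single measured step, an at least 2.0-fold higher number from compound 1 to compound 2 (0.30 log units; that floor lies within the scatter), rests on that limit of < 25 mg/kg in this assay, at which 1 of the 2 values shown sits, and concerns a different group. Compound 3 `O=C(O)c1cnc2c(Cl)cccc2c1` arises from compound 2 by chloro in place of trifluoromethyl on an aromatic carbon. For the measured compounds named here, no measured step covers this kind of change, so the estimate for compound 3 is a step of no change at the digits printed from compound 2 to compound 3 (within the scatter) that stays within the scatter. Compound 3 is therefore expected to give about 50 mg/kg, between 25 mg/kg and 100 mg/kg.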

Compound 3, minimum effective dose: 25 mg/kg
The estimate for compound 3 lay 2.0-fold (0.30 log units) above the measured number, and the stated range covers the measured number.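

In this assay, among these compounds, the swap gives a 2.0-fold lower number from compound 2 to compound 3 (0.30 log units; within the scatter) and is the first reading at this place on the ring, since the earlier step concerned the carboxy and 2H-tetrazol-5-yl groups. In this one pair, chloro, a single heavy atom, stands in for trifluoromethyl with no difference beyond the usual scatter. Nothing measured here offers a reason for this result.

From the compounds shown here alone, whether an amine, a methoxy group or a longer chain at this place would give a similar number stays open. Also open, going by these compounds, is whether chloro would give the same outcome with 2H-tetrazol-5-yl in place of carboxy.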